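A few compounds are considered here, and "the series" means these few. Any claim that something is new, unique, unknown or untested is made for them only; others in the source may bear on it.

Going by the values given here, in a functional assay on HL-60 cells (Homo sapiens) for cytotoxicity, read by WST assay, with a stated time of 48 h (a higher number here means that more compound is needed for the effect, a lower number that less compound is needed), two compounds on a shared core have numbers so far. Compound 1 (`O=C1OC[C@H](Cc2ccccc2)[C@H]1Cc1ccccc1F`) gives 72000 nM, and compound 2 (`O=C1OC[C@H](Cc2ccccc2)[C@H]1Cc1ccc(C(F)(F)F)cc1`) gives 22000 nM. Compound 2 thus holds the lower of the two numbers, and its gap to compound 1 lies beyond the scatter. Compound 3 (`O=C1OC[C@H](Cc2ccccc2)[C@H]1Cc1ccc(Cl)cc1`) has not yet been measured. It carries chloro in place of trifluoromethyl on an aromatic carbon, para to a large group: chloro in place of trifluoromethyl on an aromatic carbon. Among the compounds with values here, no step between measured compounds isolates a change at this place, so the data offer no direct guide. The expected step in this assay is small, a 1.3-fold higher number from compound 2 to compound 3 (0.10 log units; within the scatter), toward a slightly higher number and within the scatter. For compound 3 the estimate is 28000 nM, with an expected range from 12000 nM to 65000 nM.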

Compound 3, half-maximal effective concentration: 36000 nM
Beside the measured number, compound 3's estimate is 1.3-fold (0.11 log units) below it; the range from low to high includes it.
By their numbers in this assay, from the lowest: compounds 2, 3 and 1 (each within the scatter of the next, the first and the last beyond it).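

In this assay, going by these compounds alone, the exchange of trifluoromethyl for chloro on this aromatic carbon gives the first direct reading at this place (a 1.6-fold higher number from compound 2 to compound 3 (0.21 log units; within the scatter)), and the two groups cannot be told apart. The step that replaces 2-fluorophenyl with 4-chlorophenyl (a 2.0-fold lower number from compound 1 to compound 3 (0.30 log units; within the scatter)) also stays within the scatter, so compound 3 cannot be separated from either compound 1 or compound 2, although those two lie beyond the scatter of each other. Nothing measured is available to explain these results. The compounds shown leave open whether an amine or a carboxylic acid on this aromatic carbon would move the number beyond the scatter. They also leave open what chloro would do on another carbon of the same ring.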